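Chalcone biaryls on liver cancer cells: a pyridine swap

The source may hold more compounds than are shown below. What is called first, only, known or untested is meant among the compounds shown, and "the series" means these compounds.

Compound 1 `COc1ccc(C(=O)/C=C/c2ccccc2-c2ccc(F)cc2)cc1` was tested in a functional assay on HepG2 cells (Homo sapiens) for antiproliferative activity, read by sulforhodamine B assay, with a stated time of 48 h (on this read-out lower numbers stand for stronger inhibition and higher numbers for weaker inhibition), and gave 6300 nM. Compound 2 `COc1ccc(C(=O)/C=C/c2ccccc2-c2ccc(F)nc2)cc1` carries one change, (6-fluoropyridin-3-yl in place of 4-fluorophenyl on an aromatic carbon), and in this assay compound 2 gives 8200 nM. The step measured for this change was a 1.3-fold higher number from compound 1 to compound 2 (0.11 log units; within the scatter). Compound 3 `COc1cc(C(=O)/C=C/c2ccccc2-c2ccc(F)cc2)ccc1O` rests on a different core; how that core differs from the core of compound 1 is not broken down here. In this assay compound 3 gives 3100 nM, the lowest number among the three measured compounds.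

Compound 4 `COc1cc(C(=O)/C=C/c2ccccc2-c2ccc(F)nc2)ccc1O` has not yet been measured. It stands to compound 3 as compound 2 stands to compound 1: 6-fluoropyridin-3-yl in place of 4-fluorophenyl on an aromatic carbon. The surroundings of the change are described in the same words in both pairs, so it is the same change. Among the measured compounds shown here, the step from compound 3 to compound 4 is therefore expected to resemble the earlier one, a 1.3-fold higher number from compound 3 to compound 4 (0.11 log units; within the scatter), because the one measured instance of this change was a 1.3-fold higher number from compound 1 to compound 2 (0.11 log units; within the scatter). On this basis compound 4 is estimated to give 4000 nM in this assay, expected between 2000 nM and 8000 nM.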

Compound 4, half-maximal inhibitory concentration: 9900 nM
Compound 4: the middle estimate sits 2.5-fold (0.39 log units) below what was measured, and the stated range ends below it.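

In this assay the swap to 6-fluoropyridin-3-yl on the core of compound 3 gave a 3.2-fold higher number from compound 3 to compound 4 (0.50 log units; beyond the scatter), a step beyond the scatter, whereas the same swap on the core of compound 1 stayed within it. Set side by side, the two instances cannot be told apart: the same change on two cores in this assay, a 1.3-fold higher number (0.11 log units; within the scatter) from compound 1 to compound 2 and a 3.2-fold higher number (0.50 log units; beyond the scatter) from compound 3 to compound 4, 2.5-fold (0.39 log units) apart, within the scatter of two such steps. The change therefore carried from one core to the other as far as these measurements can resolve, but two instances do not fix a single size for the step, and they neither show nor exclude an influence of the core on it.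

The compounds shown leave open how other groups would behave in the place of 4-fluorophenyl, such as a thiophene, a pyrimidine, or a phenyl ring with a chlorine or an amine instead of the fluorine. From the compounds shown here alone, it also remains open whether the step would hold on further cores, for example one carrying a carboxylic acid.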